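The source may hold more compounds than are shown below. What is called first, only, known or untested is meant among the compounds shown, and "the series" means these compounds.

Compounds measured so far:
- compound 1, `CCCCOOC1(OOC)CCCCCCCCCCC1`, a functional assay on FM3A cells (Mus musculus) for cytotoxicity; a higher number here means that more compound is needed for the effect, a lower number that less compound is needed: 20000 nM
- compound 2, `CCOC(C)OOC1(OOC)CCCCCCCCCCC1`, this assay: 12000 nM

On these two numbers compound 1 stands highest, and its nearest neighbour is compound 2, reached by a 1.7-fold lower number from compound 1 to compound 2 (0.22 log units; within the scatter), with 1-ethoxyethyl in place of butyl on an oxygen. Compound 3, `COOC1(OOCCCCCCOC2CCOCC2)CCCCCCCCCCC1`, has not been measured yet. It differs from compound 1 as follows: 2-((oxan-4-yl)oxy)ethyl in place of hydrogen on a saturated chain carbon, four bonds along the chain from an oxygen. Within the data shown here, the only measured step, that from compound 1 to compound 2, alters the group on an oxygen, not a chain carbon, so it bears on the present change only in showing that a substituent swap at the edge of the shared core left the number within the scatter. Among the measured compounds shown here, no measured step addresses an addition of a 2-((oxan-4-yl)oxy)ethyl group to a chain carbon. With nothing pointing in either direction, the expected step of a 1.3-fold lower number from compound 1 to compound 3 (0.12 log units; within the scatter) is none beyond the scatter, though with a wide range. Compound 3 is therefore estimated at 15000 nM, between 4000 nM and 60000 nM.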

Compound 3, half-maximal effective concentration: 7600 nM
For compound 3 the middle estimate is 2.0-fold (0.30 log units) above the measured one; the measured number falls inside the stated range.
By their numbers in this assay, from the lowest: compounds 3, 2 and 1 (each within the scatter of the next, the first and the last beyond it).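

In this assay, adding 2-((oxan-4-yl)oxy)ethyl on a saturated chain carbon, four bonds along the chain from an oxygen, gives a 2.6-fold lower number from compound 1 to compound 3 (0.42 log units; beyond the scatter), so less compound is needed for the effect. This is the first change among these compounds whose step lies beyond the scatter, since the swap of butyl for 1-ethoxyethyl on an oxygen stayed within it, and it shows that this chain position accepts a large addition, one that brings in a six-membered ring, without any loss in this assay; the gain is modest, and it rests on a single pair of compounds. No experimental evidence is available to explain why the number moves at this position.

The compounds shown leave open whether the oxan-4-yl ring and its ether oxygen matter, or whether a plain longer alkyl chain at the same carbon would give a similar number. They also leave open how a terminal amine or a carboxylic acid in place of the oxan-4-yl ether would fare here, and whether the step would hold on a core carrying 1-ethoxyethyl on the oxygen.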